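The source may hold more compounds than are shown below. What is called first, only, known or untested is meant among the compounds shown, and "the series" means these compounds.

Compound 1 `Cc1ccc2[nH]c(C(=O)N[C@H]3CN(S(=O)(=O)c4ccnnc4)C[C@@H]3C(=O)NCCN(C)C)cc2c1`: 2.7 h
Compound 2 `Cc1ccc2[nH]c(C(=O)N[C@H]3CN(S(=O)(=O)c4cn(C)nc4C)C[C@@H]3C(=O)NCCN(C)C)cc2c1`: 2.1 h

Going by the values given here, in an ADME assay on the whole organism (Rattus norvegicus, strain Harlan-Han Wistar) for metabolic stability (a lower number here means that the compound disappears faster, a higher number that the compound lasts longer), compound 2 gives 2.1 h, and the step of a 1.3-fold lower number from compound 1 to compound 2 (0.11 log units; within the scatter) leaves it level with the only other measured compound. Compound 3 `Cc1ccc2[nH]c(C(=O)N[C@H]3CN(S(=O)(=O)C4CCOCC4)C[C@@H]3C(=O)NCCN(C)C)cc2c1` carries oxan-4-yl in place of 1,3-dimethyl-1H-pyrazol-4-yl on a sulfonyl sulfur. Among the compounds with values here, the one measured step at this place is a 1.3-fold lower number from compound 1 to compound 2 (0.11 log units; within the scatter). Within the data shown here, no measured compound has a non-aromatic ring on the sulfonyl sulfur, so this evidence is thin, and no step beyond the scatter is expected in this assay. The expected step is a 1.1-fold higher number from compound 2 to compound 3 (0.04 log units; within the scatter). For compound 3 the estimated half-life is 2.3 h, with an expected range of 1.2 h to 4.5 h.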

Compound 3, half-life: 0.2 h
Beside the measured number, compound 3's estimate is 12-fold (1.06 log units) above it; the measured number lies below the stated range.
By their numbers in this assay, from the lowest: compound 3; then compounds 2 and 1 (each within the scatter of the next).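

In this assay the group on the sulfonyl sulfur proves to matter: the result is an 11-fold lower number from compound 2 to compound 3 (1.02 log units; beyond the scatter) and a 14-fold lower number from compound 1 to compound 3 (1.13 log units; beyond the scatter) when oxan-4-yl replaces the aromatic ring. Going by these compounds alone, the two aromatic rings had stayed within the scatter of each other, so only this non-aromatic ring reveals how sensitive the position can be. Nothing available here explains the drop.

As far as these compounds go, whether it follows from the ring oxygen or from having any non-aromatic ring at this place stays open. Cyclohexyl, or an open chain such as 2-methoxyethyl, on the sulfonyl sulfur would help separate these possibilities.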